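The compounds below may be only part of what the source reports. "The series", "measured", "known", "first", "only" and "open" are said of these compounds alone.

Among the compounds with values here, compound 2 `Oc1cccc(-c2cc(-c3cccc(OC(F)(F)F)c3)cc(-c3ccccc3O)n2)c1` is one of two compounds tested in a functional assay on T47D cells (Homo sapiens) for inhibition (on this read-out higher numbers stand for weaker inhibition and lower numbers for stronger inhibition), and the only one with a definite number: compound 2 gives 5390 nM. Compound 1 `Oc1ccc(-c2cc(-c3cccc(C(F)(F)F)c3)cc(-c3ccccc3O)n2)cc1` reaches only a limit of the assay; in this assay compound 1 gives > 50000 nM, a limit and not a number, as recorded in the limit of > 50000 nM in this assay, at which 1 of the 2 values shown sits. Compound 3 `Oc1ccc(-c2cc(-c3cccc(OC(F)(F)F)c3)cc(-c3ccccc3O)n2)cc1` is not yet measured. It differs from compound 2 in one place: 4-hydroxyphenyl in place of 3-hydroxyphenyl on an aromatic carbon. No step between two measured compounds shows what this change does, so the expectation rests on the numbers shown. Compound 1, which also carries the 4-hydroxyphenyl group, gives > 50000 nM, a limit, which makes weaker inhibition the more likely direction. The expected step is a 3.7-fold higher number from compound 2 to compound 3 (0.57 log units; beyond the scatter), towards weaker inhibition. Compound 3 is therefore expected to give about 20000 nM in this assay, within a range from 6000 nM to 50000 nM, with a real chance that only a limit is reported.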

Compound 3, half-maximal inhibitory concentration: > 50000 nM
Compound 3 was reported as a limit (the forecaster's own chance of this, stated with the estimate: 40%); at least 2.5-fold (0.39 log units) between middle value and limit.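

In this assay, replacing 3-hydroxyphenyl with 4-hydroxyphenyl keeps the same atoms and only joins them differently, yet it produces an at least 9.2-fold higher number from compound 2 to compound 3 (0.96 log units; beyond the scatter), towards weaker inhibition. From the compounds shown here alone, compound 3 gives > 50000 nM, which is a limit and not a number, so the true size of this step stays unknown. This makes the position next to the ring nitrogen sensitive to where the hydroxyl group sits on the attached phenyl ring, and of the compounds shown, only compound 2, with 3-hydroxyphenyl, gives a definite number.

Going by these compounds, it remains open whether an aminophenyl or methoxyphenyl group at this position would restore or further weaken inhibition. The step from compound 1 to compound 3, the swap of trifluoromethyl for trifluoromethoxy, cannot be read, since both values are limits: the limit of > 50000 nM in this assay, at which 2 of the 3 values shown sit.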